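A few compounds are considered here, and "the series" means these few. Any claim that something is new, unique, unknown or untested is made for them only; others in the source may bear on it.

Three compounds have been measured in a functional assay on Mahlavu cells (Homo sapiens) for antiproliferative activity, read by sulforhodamine B assay, with a stated time of 72 h; a higher number here means a weaker inhibitor, a lower number a stronger inhibitor:

Compound 1, `FC(F)(F)c1ccc(CN2CCN(Cc3cc(-c4ccc(OCc5ccccc5)cc4)on3)CC2)cc1`: 11700 nM
Compound 2, `N#Cc1ccc(COc2ccc(-c3cc(CN4CCN(Cc5ccc(C(F)(F)F)cc5)CC4)no3)cc2)cc1`: 4300 nM
Compound 3, `Fc1ccc(COc2ccc(-c3cc(CN4CCN(Cc5ccc(C(F)(F)F)cc5)CC4)no3)cc2)cc1`: 3100 nM

Compound 1 stands highest of the three, so it is the weakest inhibitor shown. Replacing one of its aromatic hydrogens gave the other two: a 2.7-fold lower number from compound 1 to compound 2 (0.43 log units; beyond the scatter), and a 3.8-fold lower number from compound 1 to compound 3 (0.58 log units; beyond the scatter). Between the two replacements themselves the gap is small, a 1.4-fold lower number from compound 2 to compound 3 (0.14 log units; within the scatter).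

Compound 4, `COc1ccc(COc2ccc(-c3cc(CN4CCN(Cc5ccc(C(F)(F)F)cc5)CC4)no3)cc2)cc1`, differs from compound 1 in one place: methoxy in place of hydrogen on an aromatic carbon. Both measured steps bear on this, since each also exchanged a hydrogen on an aromatic carbon for a small group and each lowered the number by a modest amount. A step of similar size and direction is therefore expected here, though the group entering is a different one, so the size is uncertain.

The estimated step is a 2.6-fold lower number from compound 1 to compound 4 (0.41 log units; beyond the scatter). For compound 4 a value of about 4500 nM is expected, with a range from 2000 nM to 11000 nM.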

Compound 4, half-maximal inhibitory concentration: 4900 nM
The estimate for compound 4 lay 1.1-fold (0.04 log units) below the measured number; low and high end bracket the measured number.
By their numbers in this assay, from the lowest: compounds 3, 2 and 4 (each within the scatter of the next); then compound 1.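

Methoxy on this same ring carbon, para to a large group, also lowers the number in this assay, with a 2.4-fold lower number from compound 1 to compound 4 (0.38 log units; beyond the scatter), so all three groups shown here (cyano, fluoro and methoxy) give a step beyond the scatter when they take the place of hydrogen. Among the substituted compounds, the gaps stay within the scatter, with a 1.6-fold higher number from compound 3 to compound 4 (0.20 log units; within the scatter) and a 1.1-fold higher number from compound 2 to compound 4 (0.06 log units; within the scatter), so this assay does not separate these three groups from one another. No measurement shown here offers a reason for this shared step.

Going by these compounds, whether an amine or a carboxylic acid on this carbon would fit the same picture remains open. Also open, on these data alone, is whether any of these groups would give a similar step on another carbon of this ring.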